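The source may report more compounds than this note shows. Statements on the series, on what has been measured and on what is new or still open speak of the compounds shown alone.

Compound 3 `Cc1ccccc1-n1nc(C)c2c1NC(=O)[C@H](C)S[C@@H]2c1ccc(Oc2ccccc2)cc1` gives 1300 nM in an assay on isolated protein for agonist activity at Bile acid receptor (Homo sapiens), read by AlphaScreen, with a stated time of 30 min; a lower number here means that less compound is needed, a higher number that more compound is needed for the effect; this is the lowest of the two numbers shown. Compound 1 `COc1ccc(Oc2ccc([C@H]3S[C@@H](C)C(=O)Nc4c3c(C)nn4-c3ccccc3C)cc2)cc1` carries a methoxy on an aromatic carbon where compound 3 carries hydrogen; in this assay compound 1 gives 2200 nM, and the step of a 1.7-fold lower number from compound 1 to compound 3 (0.23 log units; within the scatter) lies within the scatter. Compound 2 `Cc1ccccc1-n1nc(C)c2c1NC(=O)[C@H](C)S[C@@H]2c1ccc(/C=C/c2ccccc2)cc1` is reported in this assay as "not active" (no number reported). Compound 4 `Cc1ccccc1-n1nc(C)c2c1NC(=O)[C@H](C)S[C@@H]2c1ccc(-c2ccccc2)cc1` differs from compound 3 in one place: phenyl in place of phenoxy on an aromatic carbon. Within the data shown here, no measured step bears directly on this change. Among the measured compounds shown here, the only step with a number, a 1.7-fold lower number from compound 1 to compound 3 (0.23 log units; within the scatter), alters a substituent on an aromatic carbon and is small, whereas compound 2 shows that a different change in the same region of the molecule can remove the activity altogether. The outcome for compound 4 is therefore uncertain, and a modest loss is expected rather than a gain. The expected step is a 1.9-fold higher number from compound 3 to compound 4 (0.28 log units; within the scatter). The estimate for compound 4 is 2500 nM, with a range from 700 nM to 9000 nM.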

Compound 4, half-maximal effective concentration: 990 nM
Compound 4: middle estimate off by 2.5-fold (0.40 log units), on the high side; the range from low to high includes it.
By their numbers in this assay, from the lowest: compounds 4, 3 and 1 (each within the scatter of the next, the first and the last beyond it).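

In this assay, replacing phenoxy with phenyl, para to a large group, gives (a 1.3-fold lower number from compound 3 to compound 4 (0.12 log units; within the scatter)), so at this position a phenyl attached directly to the ring serves as well as one attached through oxygen, and the ether oxygen is not needed to keep activity in this pair. Only the comparison with the 4-methoxyphenoxy group of compound 1 passes the scatter (a 2.2-fold lower number from compound 1 to compound 4 (0.35 log units; beyond the scatter)), and that step is modest. No measurement available here explains these results.

The compounds shown leave open whether the activity at this position depends on a terminal aromatic ring at all, since each compound with a number carries one. Nor do they show how a carboxylic acid or an amine on the outer phenyl of compound 4 would compare.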